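Chain ketone in place of the chain alkene

The source may hold more compounds than are shown below. What is called first, only, known or untested is meant among the compounds shown, and "the series" means these compounds.

Three compounds share one core and differ only in the acyl chain. Compound 1 `COc1cc(CNC(=O)/C=C(\C)CCC=C(C)C)ccc1O` carries a short branched unsaturated chain; in a functional assay on HEK293 cells with transient receptor potential cation channel subfamily V member 1 (Homo sapiens) as the target (a lower number here means that less compound is needed, a higher number that more compound is needed for the effect), compound 1 gives 39.8 nM. Compound 2 `CCCCCCCC/C=C\CCCCCCCCCCC(=O)NCc1ccc(O)c(OC)c1` carries a long chain with one cis double bond; in this assay compound 2 gives 3.16 nM. Compound 3 `CCCCCC[C@H](C/C=C\CCCCCCCC(=O)NCc1ccc(O)c(OC)c1)OC(C)=O` carries a long chain with a cis double bond and an acetoxy substituent; in this assay compound 3 gives 0.398 nM. On these numbers compound 2 stands second highest of the three: the gap to compound 3 is beyond the scatter, and so is the gap to compound 1.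

Compound 4 `CCCCCCC(=O)CCCCCCCCCCC(=O)NCc1ccc(O)c(OC)c1` has not been measured in this assay. It differs from compound 2 in one place: hexylcarbonyl in place of dec-1-en-1-yl on a saturated chain carbon, ten or more bonds along the chain from a carbonyl carbon. The chain thus loses its double bond and gains a ketone roughly where the double bond sat. Going by the values given here, no measured pair shows this change, so the expectation rests only on compound 2 and compound 3, both long-chain compounds with low numbers. The step is expected to be small, from compound 2 to compound 4 a 1.6-fold higher number from compound 2 to compound 4 (0.20 log units; within the scatter), with no clear direction beyond the scatter. Compound 4 is therefore expected to give about 5 nM in this assay, within a range from 1 nM to 25 nM.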

Compound 4, half-maximal effective concentration: 6.31 nM
Beside the measured number, compound 4's estimate is 1.3-fold (0.10 log units) below it, within the range that was stated.
By their numbers in this assay, from the lowest: compound 3; then compounds 2 and 4 (each within the scatter of the next); then compound 1.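

Working notes on the chain: in this assay, hexylcarbonyl in place of dec-1-en-1-yl on a saturated chain carbon, ten or more bonds along the chain from a carbonyl carbon, gives a 2.0-fold higher number from compound 2 to compound 4 (0.30 log units; within the scatter), so the two compounds cannot be told apart. Going by these compounds alone, this is the first single-place reading, since the earlier compounds differ from one another in more than one place; here, the cis double bond can give way to a ketone, with fewer heavy atoms entering than leaving and a hydrogen-bond acceptor entering where none leaves, without a step beyond the scatter. No supporting data are available to explain why this step is small.

From the compounds shown here alone, the result covers one ketone at one place on one chain, so it remains open whether a ketone further along the chain, or a different chain length, would read the same. Also open, going by these compounds, is how a hydroxyl group, an amine or a carboxylic acid would read on the same saturated chain carbon.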